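The source may report more compounds than this note shows. Statements on the series, on what has been measured and on what is new or still open speak of the compounds shown alone.

Measured so far in a physicochemical assay for acid dissociation:
compound 1 `Fc1ccc(Cc2ccc3c(NCCCNCc4ccco4)ccnc3c2)cc1` — 9.47
compound 2 `c1coc(CNCCCNc2ccnc3cc(CC4CCCCC4)ccc23)c1` — 9.47
compound 3 `COc1cccc(CNCCCNc2ccnc3cc(Cc4cccc(C(F)(F)F)c4)ccc23)c1O` — 9.47

Compound 3 stands level with compound 1 and compound 2 at the digits shown; its nearest neighbour by value is compound 1 and its furthest is compound 2, both within the scatter. Going by the values given here, the one step measured between compounds differing in a single place, no change at the digits printed from compound 1 to compound 2 (within the scatter), lies within the scatter and concerns the arylmethyl side of the shared core, not the amine side.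

Compound 4 `FC(F)(F)c1cccc(Cc2ccc3c(NCCCNCc4ccco4)ccnc3c2)c1` is the next candidate. The change from compound 3 is furan-2-yl in place of 2-hydroxy-3-methoxyphenyl on a saturated chain carbon bound to an amine nitrogen. Among the compounds with values here, no measured step touches this position in isolation. Compound 1 and compound 3 differ both at the arylmethyl and at the group on the saturated chain carbon bound to the amine nitrogen, yet compound 1 gives 9.47 and compound 3 gives 9.47, the same number. On that basis no step beyond the scatter is expected in this assay, and the expected step of no change at the digits printed from compound 3 to compound 4 (within the scatter) is taken as none. Compound 4 is therefore estimated at 9.47, with a range from 9.1 to 9.85.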

Compound 4, acid dissociation constant: 9.47
Compound 4: the middle estimate sits on the measured number at the digits printed; the range from low to high includes it.
By their numbers in this assay, from the lowest: compounds 1, 2, 3 and 4 (each within the scatter of the next).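

In this assay, the position on a saturated chain carbon bound to an amine nitrogen now has a step of its own: furan-2-yl in place of 2-hydroxy-3-methoxyphenyl gives no change at the digits printed from compound 3 to compound 4 (within the scatter) even though the hydrogen-bond donor of the leaving group goes. On a saturated chain carbon bound to an aromatic carbon, 3-(trifluoromethyl)phenyl in place of cyclohexyl gives no change at the digits printed from compound 2 to compound 4 (within the scatter) and 3-(trifluoromethyl)phenyl in place of 4-fluorophenyl gives no change at the digits printed from compound 1 to compound 4 (within the scatter) so a swap at either place on the shared core now shows no step beyond the scatter. Nothing available accounts for this flat read-out.

As far as these compounds go, whether it persists with an amine or a carboxylic acid on the saturated chain carbon bound to an amine nitrogen stays open. From the compounds shown here alone, a longer chain on the amine side is equally open.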